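A few compounds are considered here, and "the series" means these few. Any claim that something is new, unique, unknown or untested is made for them only; others in the source may bear on it.

Compound 1 `Fc1ccc(C(c2ccc(F)cc2)N2CCC3(CCN(Cc4ccc(Cl)cc4)C3)CC2)cc1`: 66%
Compound 2 `O=C(c1ccc(F)cc1)N1CCC2(CC1)CCN(Cc1ccc(Cl)cc1)C2=O`: a limit of the assay, < 20%
Compound 3 `COCCN1CCC2(CCN(C(c3ccc(F)cc3)c3ccc(F)cc3)CC2)C1=O`: 28%

In a functional assay on cells for antagonist activity at Voltage-dependent T-type calcium channel subunit alpha-1H (Homo sapiens), read by patch clamp, tested at 1 uM (a lower number here means less inhibition, a higher number more inhibition at the concentration tested (going by the name of the read-out)), compound 1 gives 66%. Compound 2 reports only a limit of the assay, < 20%. Compound 3 gives 28%, the lower of the two numbers; the nearest number, that of compound 1, stands well above it, by a gap beyond the usual scatter. The remaining value is the limit of < 20% in this assay, at which 1 of the 3 values shown sits.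

Compound 4 `CC(C)OCCCN1CCC2(CCN(C(c3ccc(F)cc3)c3ccc(F)cc3)CC2)C1=O` has not yet been measured. It differs from compound 3 in one place: isopropoxymethyl in place of methoxy on a saturated chain carbon, two bonds along the chain from an amide-type nitrogen in a ring. Going by the values given here, no pair of measured compounds that differ in a single place is available here, so the size of this change cannot be read from the data. Compound 3 to compound 4 is expected to move by a number 10 percentage points higher from compound 3 to compound 4 (within the scatter), a small rise that may well stay within the scatter. Compound 4 is therefore estimated at 38%, with a range from 20% to 62%.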

Compound 4, a percentage reported as inhibition, at one concentration (the size of the read-out at that concentration, not a potency): 76%
Compound 4: middle estimate off by 38 percentage points, on the low side; the whole stated range lies below it.
By their numbers in this assay, from the lowest: compound 3; then compounds 1 and 4 (each within the scatter of the next). At a limit, below all of these: compound 2.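

In this assay, the exchange of methoxy for isopropoxymethyl on a saturated chain carbon, two bonds along the chain from an amide-type nitrogen in a ring, gives a number 48 percentage points higher from compound 3 to compound 4 (beyond the scatter) and thus shows that the outcome at this position depends strongly on the group it carries. Going by these compounds alone, the earlier compounds included no pair differing in one place, so this is the first measured size of any change here. Nothing among the measured data accounts for the step.

The same difference also reads as 2-methoxyethyl to 3-isopropoxypropyl, so the compounds shown do not separate the longer chain from the isopropyl ether end. Open, as far as these compounds go, is whether a 3-methoxypropyl or a 2-isopropoxyethyl group would carry the rise, and what an amine or a carboxylic acid at the chain end would do.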